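Pyridin-2-yl in place of 4-methylphenyl: an expectation

A few compounds are considered here, and "the series" means these few. Any claim that something is new, unique, unknown or untested is made for them only; others in the source may bear on it.

Compound 1 `Cc1ccc(N2CCN(C(=S)SCc3ccc4nc(N)nc(N)c4c3)CC2)cc1`: 2130 nM
Compound 2 `Cc1ccc(N2CCN(C(=S)SCc3ccc4nc(N)nc(N)c4c3)CC2)c(C)c1`: 3190 nM

In a functional assay on HeLa cells (Homo sapiens) for antiproliferative activity, read by MTT assay, with a stated time of 72 h (a lower number here means a stronger inhibitor, a higher number a weaker inhibitor), compound 1 gives 2130 nM, the lowest of the two numbers. Compound 2 gives 3190 nM, and a 1.5-fold higher number from compound 1 to compound 2 (0.18 log units; within the scatter) lies within the scatter. Compound 3 `Nc1nc(N)c2cc(CSC(=S)N3CCN(c4ccccn4)CC3)ccc2n1` has not been measured; it differs from compound 1 by pyridin-2-yl in place of 4-methylphenyl on an amine nitrogen in a ring. Going by the values given here, the only measured step, a 1.5-fold higher number from compound 1 to compound 2 (0.18 log units; within the scatter), alters the same ring but does not exchange it, so it bears only loosely on this change and stayed within the scatter. For compound 3 no step beyond the scatter is expected, a 1.2-fold higher number from compound 1 to compound 3 (0.07 log units; within the scatter). Compound 3 is estimated at 2500 nM, within a range of 900 nM to 7000 nM.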

Compound 3, half-maximal inhibitory concentration: 5090 nM
Estimate against measurement, compound 3: 2.0-fold (0.31 log units) below, and the stated range covers the measured number.
By their numbers in this assay, from the lowest: compounds 1, 2 and 3 (each within the scatter of the next, the first and the last beyond it).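

Going by these compounds alone, replacing 4-methylphenyl with pyridin-2-yl on the amine nitrogen in the ring gives the first step beyond the scatter, though a modest one, with a 2.4-fold higher number from compound 1 to compound 3 (0.38 log units; beyond the scatter) as the result. Measured against the 2,4-dimethylphenyl group, the exchange stays within the scatter, with a 1.6-fold higher number from compound 2 to compound 3 (0.20 log units; within the scatter) as the result, so only the comparison with compound 1 shows a clear change. Nothing measured here explains the difference.

Compound 3 both gains a ring nitrogen and loses the methyl of compound 1, so these two changes cannot be told apart. From the compounds shown here alone, a plain phenyl group at this position would separate them, and how a pyridine ring carrying a methyl group would compare also remains open.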